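Moving the chloro group: compound 3 to compound 4

The source may hold more compounds than are shown below. What is called first, only, known or untested is meant among the compounds shown, and "the series" means these compounds.

- Compound 1 `CC1=CC[C@@H]([C@@](C)(O)CCCC(C)(C)NC(=S)N/N=C\c2ccccc2)CC1` (38400 nM)
- Compound 2 `CC1=CC[C@@H]([C@@](C)(O)CCCC(C)(C)NC(=S)N/N=C\c2ccc([N+](=O)[O-])cc2)CC1` (10100 nM)
- Compound 3 `CC1=CC[C@@H]([C@@](C)(O)CCCC(C)(C)NC(=S)N/N=C\c2cccc(Cl)c2)CC1` (44300 nM)

In a functional assay on NCI-H460 cells (Homo sapiens) for cytotoxicity, read by sulforhodamine B assay (on this read-out lower numbers stand for stronger inhibition of growth and higher numbers for weaker inhibition of growth), compound 3 (44300 nM) matches compound 1 within the scatter, and the gap from the nitro compound is a 4.4-fold higher number from compound 2 to compound 3 (0.64 log units; beyond the scatter) and counts as modest. Compound 4 `CC1=CC[C@@H]([C@@](C)(O)CCCC(C)(C)NC(=S)N/N=C\c2ccc(Cl)cc2)CC1` carries 4-chlorophenyl in place of 3-chlorophenyl on a carbon with a double bond to nitrogen. Chloro in place of hydrogen gave a 1.2-fold higher number from compound 1 to compound 3 (0.06 log units; within the scatter) while nitro in the 4-nitrophenyl group gave a 3.8-fold lower number from compound 1 to compound 2 (0.58 log units; beyond the scatter) and no measured step moves a chloro group. Only a small shift is therefore expected, namely a 1.5-fold lower number from compound 3 to compound 4 (0.17 log units; within the scatter) and so nothing beyond the scatter. The estimated value for compound 4 is 30000 nM (expected range 12000 nM to 60000 nM).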

Compound 4, concentration for 50% growth inhibition: 8720 nM
Compound 4: the middle estimate sits 3.4-fold (0.54 log units) above what was measured, outside the stated range (below it).
By their numbers in this assay, from the lowest: compounds 4 and 2 (each within the scatter of the next); then compounds 1 and 3 (each within the scatter of the next).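

Moving the chloro group alone matters in this assay: 4-chlorophenyl in place of 3-chlorophenyl gives a 5.1-fold lower number from compound 3 to compound 4 (0.71 log units; beyond the scatter) with the same atoms joined differently. Compared with the plain phenyl group, chloro in the 4-chlorophenyl group gives a 4.4-fold lower number from compound 1 to compound 4 (0.64 log units; beyond the scatter) even though chloro in compound 3 brought no clear change. Chloro in place of nitro gives a 1.2-fold lower number from compound 2 to compound 4 (0.06 log units; within the scatter) and so leaves those two compounds level.

From the compounds shown here alone, whether a 4-methoxyphenyl or 4-aminophenyl group would match compound 4 remains open. Nothing measured here gives a cause for the shift between the two chloro compounds.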